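Replacing a methyl by methylsulfonyl on the amine nitrogen

A few compounds are considered here, and "the series" means these few. Any claim that something is new, unique, unknown or untested is made for them only; others in the source may bear on it.

Compound 1 `CN(C)CCCn1cc[n+](C)c1/C=N/O`: < -3
Compound 2 `C[n+]1ccn(CC[N+](C)(C)C)c1/C=N/O`: -2.61

In a physicochemical assay for lipophilicity (on this read-out lower numbers stand for lower lipophilicity and higher numbers for higher lipophilicity), compound 1 gives < -3, which is a limit of the assay rather than a number (the limit of < -3 in this assay, at which 1 of the 2 values shown sits). Compound 2 gives -2.61 in this assay. For the measured compounds named here, the only measured step is a number at least 0.39 log units higher from compound 1 to compound 2 (beyond the scatter). Compound 3 `CN(CCCn1cc[n+](C)c1/C=N/O)S(C)(=O)=O` differs from compound 1 by methylsulfonyl in place of methyl on an amine nitrogen. No measured step covers this change; the one step shown indicates only that a change at this chain end can move this assay upward beyond the scatter. Compound 3 is therefore expected to come off the limit, with an estimated step of a number at least 1.00 log units higher from compound 1 to compound 3 (beyond the scatter). The estimated value of compound 3 in this assay is -2, in the range -2.8 to -1.2.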

Compound 3, distribution coefficient: -2.63
Estimate against measurement, compound 3: 0.63 log units above; the range from low to high includes it.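

In this assay, methylsulfonyl in place of methyl on an amine nitrogen gives a number at least 0.37 log units higher from compound 1 to compound 3 (beyond the scatter) and so lifts the reading clear of the limit. The earlier compounds shown here showed this only for a different group at the chain end, not for a change on this amine nitrogen. On these data alone, the true size of the step remains unknown because the value for compound 1 is a limit: the limit of < -3 in this assay, at which 1 of the 3 values shown sits. The compounds shown leave open how an acetyl group on this amine nitrogen would read, and whether a longer chain carrying methylsulfonyl would read the same.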